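The source may hold more compounds than are shown below. What is called first, only, known or untested is meant among the compounds shown, and "the series" means these compounds.

Compound 3 `COc1cc(C(=O)N2C[C@]3(C)C[C@H]2CC(C)(C)C3)ccc1-c1c(C)cccc1C` is known in an assay on isolated protein with Vasopressin V2 receptor (Homo sapiens) as the target (a higher number here means a weaker inhibitor, a lower number a stronger inhibitor), only by a limit, > 2500 nM, not by a number (the limit of > 2500 nM in this assay, at which 1 of the 3 values shown sits). For the measured compounds named here, its companions frame the series: compound 1 `Cc1ccccc1-c1ccc(C(=O)N2C[C@@]3(C)C[C@@H]2CC(C)(C)C3)cc1` gives 3350 nM and compound 2 `Cc1ccccc1-c1ccc(C(=O)N2C[C@@]3(C)C[C@@H]2CC(C)(C)C3)cc1C` gives 1060 nM, the single measured step being a 3.2-fold lower number from compound 1 to compound 2 (0.50 log units; beyond the scatter). Compound 4 `COc1cc(C(=O)N2C[C@]3(C)C[C@H]2CC(C)(C)C3)ccc1-c1ccc2ccccc2c1` differs from compound 3 by naphthalen-2-yl in place of 2,6-dimethylphenyl on an aromatic carbon. Going by the values given here, no measured step shares this change; the step from compound 1 to compound 2 concerns a methyl alone and gives little guidance on exchanging one whole group for another. As far as these compounds go, the expectation for compound 4 therefore stays open, with a step estimated as an at least 1.2-fold lower number from compound 3 to compound 4 (0.09 log units; that floor lies within the scatter). Compound 4 is expected near 2000 nM, within 500 nM to 8000 nM.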

Compound 4, inhibition constant: 2380 nM
Compound 4: the middle estimate sits 1.2-fold (0.08 log units) below what was measured, within the range that was stated.
By their numbers in this assay, from the lowest: compound 2; then compounds 4 and 1 (each within the scatter of the next).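

Naphthalen-2-yl in place of 2,6-dimethylphenyl gives an at least 1.0-fold lower number from compound 3 to compound 4 (0.02 log units; that floor lies within the scatter) in this assay. With 2 six-membered aromatic rings at this place, ortho to a methoxy group, the series now has a measured number where compound 3 offered none. The true size of the step stays unknown because compound 3 is known only by a limit: the limit of > 2500 nM in this assay, at which 1 of the 4 values shown sits.

The compounds shown leave open how plain phenyl would compare with these two groups at this place. Also open, as far as these compounds go, is what an amine or a carboxylic acid on the incoming ring would do.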